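A few compounds are considered here, and "the series" means these few. Any claim that something is new, unique, unknown or untested is made for them only; others in the source may bear on it.

Compound 1 `C[C@@H](O[C@H]1CN2C(=O)C=C(c3ccc(F)cc3)CC2[C@@H]1c1ccc(F)cc1)c1cc(C(F)(F)F)cc(C(F)(F)F)c1` gives 100 nM in an assay on CHO cells for displacement of a labelled ligand from Substance-P receptor (Homo sapiens), in the presence of a further agent that is not named here; a lower number here means a stronger inhibitor, a higher number a weaker inhibitor. Compound 2 `C[C@@H](O[C@H]1CN2C(=O)C=C(c3ccc(NS(C)(=O)=O)cc3)CC2[C@@H]1c1ccc(F)cc1)c1cc(C(F)(F)F)cc(C(F)(F)F)c1` gives 54 nM, and the step of a 1.9-fold lower number from compound 1 to compound 2 (0.27 log units; within the scatter) stays within the scatter. Compound 3 `C[C@@H](O[C@H]1CN2C(=O)C=C(c3ccc(CO)cc3)CC2[C@@H]1c1ccc(F)cc1)c1cc(C(F)(F)F)cc(C(F)(F)F)c1` gives 23 nM, the lowest of the three numbers; the steps of a 4.3-fold lower number from compound 1 to compound 3 (0.64 log units; beyond the scatter) and a 2.3-fold lower number from compound 2 to compound 3 (0.37 log units; beyond the scatter) are both modest but beyond the scatter, so compound 3 is the strongest inhibitor shown.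

Compound 4 `C[C@@H](O[C@H]1CN2C(=O)C=C(c3ccncc3)CC2[C@@H]1c1ccc(F)cc1)c1cc(C(F)(F)F)cc(C(F)(F)F)c1` differs from compound 3 in one place: pyridin-4-yl in place of 4-(hydroxymethyl)phenyl on a double-bonded ring carbon. All three measured steps change only the group on that same aromatic ring, and none replaces the ring itself, so they bear on this change only loosely. Compound 4, like compound 1, carries no hydrogen-bond donor at this position; compound 1 sits at 100 nM, while compound 3 with its hydroxymethyl sits lower. The expected step of a 2.6-fold higher number from compound 3 to compound 4 (0.42 log units; beyond the scatter) is therefore a modest rise in the number, toward the range of compound 1. For compound 4 the estimated value in this assay is 60 nM, with a plausible range from 20 nM to 200 nM.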

Compound 4, half-maximal inhibitory concentration: 8.1 nM
Compound 4: the middle estimate sits 7.4-fold (0.87 log units) above what was measured; the measured number lies below the stated range.
By their numbers in this assay, from the lowest: compound 4; then compound 3; then compounds 2 and 1 (each within the scatter of the next).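

At this double-bonded ring carbon the substituted phenyl ring can give way to a ring holding nitrogen: pyridin-4-yl brings a 2.8-fold lower number from compound 3 to compound 4 (0.45 log units; beyond the scatter) in this assay and also a 6.7-fold lower number from compound 2 to compound 4 (0.82 log units; beyond the scatter) and a 12-fold lower number from compound 1 to compound 4 (1.09 log units; beyond the scatter) as it reaches the lowest number of the four. Compound 4 has no hydrogen-bond donor in this group, so the hydroxymethyl donor of compound 3 is not required for a low number here. Nothing measured here explains why this ring does better.

The compounds shown leave open whether the gain goes with the ring nitrogen or with the loss of the group on the ring, a question an unsubstituted phenyl would help to settle. Pyridin-3-yl and pyrimidinyl rings would show whether the place and number of ring nitrogens matter.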